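Urea aryl variation on the shared thienopyrimidine series

The compounds below may be only part of what the source reports. "The series", "measured", "known", "first", "only" and "open" are said of these compounds alone.

Measured so far in a functional assay on HT-29 cells (Homo sapiens) for cytotoxicity, read by MTT assay, with a stated time of 72 h; a lower number here means a stronger inhibitor, a higher number a weaker inhibitor:
compound 1 `CN(C)CCCNc1nc(-c2ccc(NC(=O)Nc3ccc(Cl)cc3Cl)cc2)nc2c(Cl)c(Cl)sc12` gives 1320 nM
compound 2 `CCN(CC)CCCNc1nc(-c2ccc(NC(=O)Nc3ccc(F)cc3)cc2)nc2c(Cl)c(Cl)sc12` gives 350 nM
compound 3 `CCN(CC)CCCNc1nc(-c2ccc(NC(=O)Nc3ccccc3Cl)cc2)nc2c(Cl)c(Cl)sc12` gives 410 nM

Compound 3 holds the second highest number of the three. Compound 2 lies nearest, a 1.2-fold higher number from compound 2 to compound 3 (0.07 log units; within the scatter). Among the measured compounds shown here, compound 1 lies furthest, its number higher than that of compound 3 beyond the scatter; compound 1, however, differs from compound 3 in two places, the amine as well as the urea aryl, so no single step is read from it.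

Compound 4 `CCN(CC)CCCNc1nc(-c2ccc(NC(=O)Nc3ccc(Cl)cc3Cl)cc2)nc2c(Cl)c(Cl)sc12` carries the change (chloro in place of hydrogen on an aromatic carbon). For the measured compounds named here, only the step from compound 2 to compound 3 bears on changes at the urea aryl, and it stayed within the scatter. That compound 1, also bearing the 2,4-dichlorophenyl, gives a higher number suggests some movement upward, though its amine is not the same. For compound 4 a modest rise is expected, a 1.7-fold higher number from compound 3 to compound 4 (0.23 log units; within the scatter), with the estimate 700 nM in a range of 300 nM to 1600 nM in this assay.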

Compound 4, half-maximal inhibitory concentration: 1230 nM
Estimate against measurement, compound 4: 1.8-fold (0.24 log units) below, within the range that was stated.
By their numbers in this assay, from the lowest: compounds 2 and 3 (each within the scatter of the next); then compounds 4 and 1 (each within the scatter of the next).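

In this assay, among the compounds shown here, chloro in place of hydrogen on the urea aryl, para to a large group, gives the first step at this aryl beyond the scatter, a 3.0-fold higher number from compound 3 to compound 4 (0.48 log units; beyond the scatter) and, against the 4-fluorophenyl, a 3.5-fold higher number from compound 2 to compound 4 (0.55 log units; beyond the scatter). With 2,4-dichlorophenyl held fixed, diethylamino in place of dimethylamino gives a 1.1-fold lower number from compound 1 to compound 4 (0.03 log units; within the scatter), so the amine change shows no shift on this aryl. No measurement shown accounts for the rise at the urea aryl.

Open, on these data alone, is how a lone 4-chlorophenyl or a 4-methoxyphenyl on the urea would read. Also open, as far as these compounds go, is morpholine in place of the diethylamino group.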